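The compounds below may be only part of what the source reports. "The series", "measured", "known", "first", "only" and "open" are said of these compounds alone.

Compound 3 `Cc1cc(C)n2nc(N(C)C)c(S(=O)(=O)c3ccccc3)c2n1` gives 14.5 nM in a functional assay on HEK293 cells for antagonist activity at 5-hydroxytryptamine receptor 6 (Homo sapiens), read by cAMP accumulation, with a stated time of 2 h (on this read-out higher numbers stand for weaker inhibition and lower numbers for stronger inhibition), the lowest of the three numbers. Compound 1 `Cc1cc(C)n2nc(C)c(S(=O)(=O)c3ccccc3)c2n1` gives 88.8 nM, and compound 2 `Cc1cc(C)n2nc(NCCN(C)C)c(S(=O)(=O)c3ccccc3)c2n1` gives 2600 nM. Compound 4 `Cc1cc(C)n2nc(N3CCNCC3)c(S(=O)(=O)c3ccccc3)c2n1` differs from compound 3 by piperazin-1-yl in place of dimethylamino on an aromatic carbon. Among the compounds with values here, two measured steps bear on this change: a 6.1-fold lower number from compound 1 to compound 3 (0.79 log units; beyond the scatter), and a 180-fold lower number from compound 2 to compound 3 (2.25 log units; beyond the scatter), where a flexible chain carrying a second nitrogen cost a great deal. The piperazin-1-yl group keeps the ring-bound nitrogen of compound 3 but adds a second nitrogen in a ring, so a modest weakening is expected, short of what compound 2 showed. Compound 4 is therefore estimated at 60 nM, between 10 nM and 400 nM, an expected step of a 4.1-fold higher number from compound 3 to compound 4 (0.62 log units; beyond the scatter).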

Compound 4, inhibition constant: 1380 nM
Estimate against measurement, compound 4: 23-fold (1.36 log units) below; measured number outside the range, above it.
By their numbers in this assay, from the lowest: compound 3; then compound 1; then compounds 4 and 2 (each within the scatter of the next).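

At this aromatic carbon, piperazin-1-yl loses almost all that dimethylamino gave, with a 95-fold higher number from compound 3 to compound 4 (1.98 log units; beyond the scatter) in this assay. Tying the second nitrogen into a ring does not recover what the open chain lost, as a 1.9-fold lower number from compound 2 to compound 4 (0.28 log units; within the scatter) shows. Even the small methyl group does better, with a 16-fold higher number from compound 1 to compound 4 (1.19 log units; beyond the scatter), so a nitrogen bound directly to this carbon does not by itself give strong inhibition.

From the compounds shown here alone, whether the loss follows the second ring nitrogen or the ring itself stays open, and a piperidine or morpholine ring at this carbon would separate the two. Nothing measured here explains the loss.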